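A few compounds are considered here, and "the series" means these few. Any claim that something is new, unique, unknown or untested is made for them only; others in the source may bear on it.

Working notes on the series. In a functional assay on HCT-116 cells (Homo sapiens) for inhibition, read by MTT assay, with a stated time of 48 h (a lower number here means a stronger inhibitor, a higher number a weaker inhibitor), compound 1 (`COc1ccc(-c2cc(-c3cc(OC)c(OC)c(OC)c3)nc(-c3ccccc3)n2)cc1`) gives 4780 nM and compound 2 (`COc1cc(-c2cc(-c3ccc(O)cc3)nc(-c3ccccc3)n2)cc(OC)c1OC`) gives 11900 nM, the higher of the two numbers, which makes compound 2 the weaker inhibitor of this pair. The next change leads to compound 3 (`COc1cc(-c2cc(-c3ccc(O)cc3O)nc(-c3ccccc3)n2)cc(OC)c1OC`): hydroxy in place of hydrogen on an aromatic carbon, so that 4-hydroxyphenyl becomes 2,4-dihydroxyphenyl. For the measured compounds named here, only one measured step bears on this change: a 2.5-fold higher number from compound 1 to compound 2 (0.40 log units; beyond the scatter), with hydrogen in place of methyl on an oxygen on an aromatic ring. That step is modest and it is a different change, so it is only a loose guide. A similarly modest step towards a higher number in this assay is expected, though one within the scatter cannot be excluded. The estimated move is a 1.3-fold higher number from compound 2 to compound 3 (0.13 log units; within the scatter). The expected value for compound 3 is 16000 nM, with an estimated range of 6000 nM to 40000 nM.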

Compound 3, half-maximal inhibitory concentration: 5890 nM
Compound 3: middle estimate off by 2.7-fold (0.43 log units), on the high side; measured number below the stated range.
By their numbers in this assay, from the lowest: compounds 1 and 3 (each within the scatter of the next); then compound 2.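

In this assay, for the compounds shown here, hydroxy in place of hydrogen on an aromatic carbon, ortho to a large group and meta to a hydroxy group, gives a 2.0-fold lower number from compound 2 to compound 3 (0.31 log units; beyond the scatter) and is the first step towards a lower number. Set against the 4-methoxyphenyl of compound 1, the 2,4-dihydroxyphenyl of compound 3 gives a 1.2-fold higher number from compound 1 to compound 3 (0.09 log units; within the scatter) and so is not told apart from it in this assay. No measured evidence on hand accounts for the step from compound 2 to compound 3.

From the compounds shown here alone, whether methoxy, fluorine or an amine at the same position would give a similar number remains open. Also open, going by these compounds, is whether this position gives the same step when the 4-hydroxy group is replaced by a methoxy group.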